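A few compounds are considered here, and "the series" means these few. Any claim that something is new, unique, unknown or untested is made for them only; others in the source may bear on it.

Measured so far:
compound 1, `COc1ncc(-c2ccc(-c3cnc4c(c3)CN(C)C4=O)s2)cc1NS(=O)(=O)c1ccccc1[N+](=O)[O-]`, 4810 ug/mL;
compound 2, `CN1Cc2cc(-c3ccc(-c4cncc(NS(=O)(=O)c5ccccc5C(F)(F)F)c4)s3)cnc2C1=O`, 4280 ug/mL.

In a physicochemical assay for solubility, read by HPLC (a higher number here means a more soluble compound, a lower number a less soluble compound), compound 1 gives 4810 ug/mL, and compound 2 gives 4280 ug/mL. The two numbers lie within the usual scatter of each other, so neither compound can be called the more soluble one on this evidence; both dissolve well.

Compound 3, `COc1ncc(-c2ccc(-c3cnc4c(c3)CN(C)C4=O)s2)cc1NS(=O)(=O)c1ccccc1C(F)(F)F`, has not yet been measured. It is compound 2 with one change: methoxy in place of hydrogen on an aromatic carbon. The shared core and the rest of the molecule stay as they are.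

Going by the values given here, no pair of measured compounds differs in one place, so there is no measured step to lean on. Given how close compound 1 and compound 2 sit, the change is expected to move this assay by little, if at all: a 1.1-fold higher number from compound 2 to compound 3 (0.02 log units; within the scatter) is the estimated step, within the scatter. Compound 3 is therefore expected to give about 4500 ug/mL, likely between 2500 ug/mL and 8000 ug/mL.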

Compound 3, solubility: 7340 ug/mL
The estimate for compound 3 lay 1.6-fold (0.21 log units) below the measured number; measured number inside the range.
By their numbers in this assay, from the lowest: compounds 2, 1 and 3 (each within the scatter of the next).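

In this assay, putting methoxy in place of hydrogen on an aromatic carbon, next to the ring nitrogen, gives a 1.7-fold higher number from compound 2 to compound 3 (0.23 log units; within the scatter), so repeat measurements could not tell this step from no change at all. With methoxy kept at that position, trifluoromethyl in place of nitro on an aromatic carbon gives a 1.5-fold higher number from compound 1 to compound 3 (0.18 log units; within the scatter), so neither change can be said to move the number. Nothing available bears on why the numbers fall where they do.

Still open, as far as these compounds go, is whether an amine, a carboxylic acid or a longer chain at this position would move the number beyond the scatter. Also open, from the compounds shown here alone, is whether the methoxy step would look the same with nitro in place of trifluoromethyl.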